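A few compounds are considered here, and "the series" means these few. Any claim that something is new, unique, unknown or untested is made for them only; others in the source may bear on it.

Of the compounds shown here, two sharing one core have been measured so far. Compound 1 `COc1ccc(C)cc1N1C(=O)CSC1c1cccc(C(=O)NCCCCc2ccccc2)c1` carries a group of 9 heavy atoms on an amide-type nitrogen in a ring; in a functional assay on 143B cells (Homo sapiens) for inhibition, read by CCK-8 assay, with a stated time of 72 h, tested at 1 uM (on this read-out higher numbers stand for more inhibition at the one concentration tested (going by the name of the read-out) and lower numbers for less inhibition), compound 1 gives 29%. Compound 2 `CC(F)(F)c1cccc(N2C(=O)CSC2c2cccc(C(=O)NCCCCc3ccccc3)c2)c1` carries instead a group of 10 heavy atoms at the same place; in this assay compound 2 gives 1%. Going by the values given here, that single swap produced a number 28 percentage points lower from compound 1 to compound 2 (beyond the scatter), so compound 2 stands lowest of the two numbers, with compound 1 as its only neighbour.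

Compound 3 `O=C(NCCCCc1ccccc1)c1cccc(C2SCC(=O)N2c2ccccc2F)c1` is the next compound to be measured. The change from compound 2 is a group of 7 heavy atoms (6 carbon, 1 fluorine; one six-membered aromatic ring of carbon only) in place of a group of 10 heavy atoms (8 carbon, 2 fluorine; one six-membered aromatic ring of carbon only), on an amide-type nitrogen in a ring. Among the compounds with values here, only the step from compound 1 to compound 2 bears on this, and it shows that what sits on this ring nitrogen can move the read-out by a modest amount, with the smaller, oxygen-bearing group giving the higher number. Because compound 2 sits at 1%, there is little room to fall, and a return of part of the earlier loss is plausible, so a rise of about a number 14 percentage points higher from compound 2 to compound 3 (beyond the scatter) is expected. Compound 3 is therefore estimated to give 15%, with a range of 0% to 35%.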

Compound 3, a percentage reported as inhibition, at one concentration (the size of the read-out at that concentration, not a potency): 59%
Compound 3: middle estimate off by 44 percentage points, on the low side; measured number outside the range, above it.
By their numbers in this assay, from the lowest: compound 2; then compound 1; then compound 3.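

In this assay, replacing the larger group on the amide-type nitrogen with 2-fluorophenyl gives a number 58 percentage points higher from compound 2 to compound 3 (beyond the scatter), so this position can carry a far larger change than the first pair showed. The same group also gives a number 30 percentage points higher from compound 1 to compound 3 (beyond the scatter), so a group without oxygen can surpass the oxygen-bearing one, and fluorine alone does not settle the outcome, as compound 2 and compound 3 both carry it. Across these three compounds, the number rises as the group on this nitrogen has fewer heavy atoms, with none going against that order, although three compounds make a thin basis and nothing measured here explains the rise.

On these data alone, what remains open is whether the fluorine of compound 3 matters at all, which a plain phenyl group on the same nitrogen would help to test, as would a chlorine atom in its place. A single reading at one concentration also gives no potency, so a full concentration series would be needed to show how far compound 3 truly stands above compound 1.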